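Working notes: from compound 3 to compound 4

This account rests on a few compounds, and the source may have more. Where it says the series, first, only, none or still open, it means among the compounds named here.

Compound 1 (`CCCCCCCCc1ccc(OCC(=O)Cn2ncnn2)cc1`) gives < 5% in an ADME assay on S9 fraction from liver (Rattus norvegicus) for metabolic stability, read by LC-MS, using NADPH, with a stated time of 30 min (on this read-out higher numbers stand for a more stable compound and lower numbers for a less stable compound), which is a limit of the assay. Compound 2 (`CCCCCCCCc1ccc(OCC(=O)Cn2nnc(C(=O)OC)n2)cc1`) gives < 5%, also a limit. Compound 3 (`CCCCCCCCc1ccc(OCC(=O)Cn2nnnc2-c2ccccn2)cc1`) stands at < 5%, again a limit and not a number. Compound 4 (`CCCCCCCCc1ccc(OCC(=O)Cn2nnnc2C(=O)OC)cc1`) differs from compound 3 by methoxycarbonyl in place of pyridin-2-yl on an aromatic carbon, with methoxycarbonyl in place of pyridin-2-yl on an aromatic carbon. Within the data shown here, the one measured step bringing in methoxycarbonyl is a step that the two limits leave unreadable from compound 1 to compound 2, so its size gives no guide. Among the measured compounds shown here, the series so far offers only (the limit of < 5% in this assay, at which 3 of the 3 values shown sit). No step beyond the scatter is therefore expected in this assay, and no direction is expected. The estimated step is a step that the limit leaves unreadable from compound 3 to compound 4. Compound 4 is expected at 3%, with an estimated range of 1% to 8%.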

Compound 4, percent of the compound remaining: 38%
Estimate against measurement, compound 4: 35 percentage points below, outside the stated range (above it).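

In this assay, methoxycarbonyl in place of pyridin-2-yl on the aromatic carbon gives a number at least 33 percentage points higher from compound 3 to compound 4 (beyond the scatter). With methoxycarbonyl present in both compounds, 5-(methoxycarbonyl)-1H-tetrazol-1-yl in place of 5-(methoxycarbonyl)-2H-tetrazol-2-yl gives a number at least 33 percentage points higher from compound 2 to compound 4 (beyond the scatter), so methoxycarbonyl alone does not decide the read-out. Against the unsubstituted 2H-tetrazol-2-yl, the same group gives a number at least 33 percentage points higher from compound 1 to compound 4 (beyond the scatter), the first readable value in a series otherwise held at a limit: the limit of < 5% in this assay, at which 3 of the 4 values shown sit.

Still open, from the compounds shown here alone, is whether a carboxylic acid or an amide on this aromatic carbon holds the read-out as methoxycarbonyl does. Also open, going by these compounds, is whether a shorter chain on the shared core changes it.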